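A Chloro Step from the Highest Compound

A few compounds are considered here, and "the series" means these few. Any claim that something is new, unique, unknown or untested is made for them only; others in the source may bear on it.

Going by the values given here, in a functional assay on NCI-H522 cells (Homo sapiens) for inhibition, read by sulforhodamine B assay, with a stated time of 48 h, tested at 10 uM (on this read-out higher numbers stand for more inhibition of growth at the one concentration tested and lower numbers for less inhibition of growth), compound 2 (`COc1ccc(-c2nc3sc(-c4ccccc4)cn3n2)cc1`) gives 70% and stands highest of the three numbers so far. In this assay compound 1 (`C/C(=N\O)c1ccc(NC(=O)Cn2nc(-c3ccc(Cl)cc3)nc2N)cc1`) gives 31.5% and compound 3 (`C/C(=N/O)c1ccc(NC(=O)Cn2nc(C(F)(F)F)nc2N)cc1`) gives 31% and both lie lower than compound 2 by more than the scatter. Compound 4 (`COc1ccc(-c2nc3sc(-c4ccc(Cl)cc4)cn3n2)cc1`) differs from compound 2 by one change (chloro in place of hydrogen on an aromatic carbon) that puts chloro in place of hydrogen on an aromatic carbon. Among the compounds with values here, no measured pair shows this change, so the expectation rests on compound 2 (70%) alone. The expected step of a number 2 percentage points higher from compound 2 to compound 4 (within the scatter) is small and is estimated to stay within the scatter, with no firm direction. The estimated value for compound 4 is 72% with an expected range from 50% to 90% (not yet measured).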

Compound 4, percent growth inhibition at one concentration: 39%
Beside the measured number, compound 4's estimate is 33 percentage points above it, and the stated range ends above it.
By their numbers in this assay, from the lowest: compounds 3, 1 and 4 (each within the scatter of the next); then compound 2.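

In this assay, going by these compounds alone, the place on the six-membered aromatic ring para to a large group proves sensitive: phenyl to 4-chlorophenyl gives a number 31 percentage points lower from compound 2 to compound 4 (beyond the scatter) and is not the small change the earlier compounds left possible. A single chlorine in place of hydrogen is enough for this loss of growth inhibition, though this rests on one pair only. Nothing available bears on the reason for this drop. On these data alone, whether fluoro, a methyl group or an amine at this same place would lower the number as far remains open. So does whether chloro would have the same effect elsewhere on the core.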